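The source may hold more compounds than are shown below. What is called first, only, known or untested is meant among the compounds shown, and "the series" means these compounds.

Measured compounds:
- compound 1, `COc1ccc(-c2c(S(=O)(=O)c3ccc(F)cc3)cnc3cc(F)ccc23)cc1`: 1.77 mL/min
- compound 2, `COc1ccc(-c2c(S(=O)(=O)c3ccc(C)c(C)c3)cnc3cc(F)ccc23)cc1`: 4.13 mL/min
- compound 3, `COc1ccc(-c2c(S(=O)(=O)c3cc(Cl)cc(Cl)c3)cnc3cc(F)ccc23)cc1`: 1 mL/min

In an ADME assay on microsomes from liver (Homo sapiens) for metabolic stability, tested at 2.5 uM (on this read-out lower numbers stand for slow clearance and higher numbers for fast clearance), compound 2 gives the highest number of the three. Compound 1 sits nearest to it, and the step of a 2.3-fold higher number from compound 1 to compound 2 (0.37 log units; beyond the scatter) lies beyond the scatter; compound 3 sits furthest, and the step of a 4.1-fold lower number from compound 2 to compound 3 (0.62 log units; beyond the scatter) also lies beyond the scatter. The step of a 1.8-fold lower number from compound 1 to compound 3 (0.25 log units; within the scatter) stays within the scatter.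

Compound 4, `Cc1ccc(S(=O)(=O)c2cnc3cc(F)ccc3c2-c2cccc(F)c2)cc1C`, has not yet been measured. It differs from compound 2 in one place: 3-fluorophenyl in place of 4-methoxyphenyl on an aromatic carbon.

All three measured steps change the group on the sulfonyl sulfur; none of them touches the aromatic carbon where compound 4 differs from compound 2. Going by the values given here, there is therefore no measured step that bears on this change, and no basis in these data for expecting a shift in either direction. The safest expectation is a step that stays within the scatter, with a wide range to allow for the absence of any relevant comparison.

The estimated step of a 1.0-fold lower number from compound 2 to compound 4 (0.01 log units; within the scatter) is expected to stay within the scatter. For compound 4 the expected value in this assay is 4 mL/min, within a range of 1.5 mL/min to 10 mL/min.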

Compound 4, intrinsic clearance in a liver preparation (reported as CLH), per the amount of preparation that the assay uses: 3.71 mL/min
For compound 4 the middle estimate is 1.1-fold (0.03 log units) above the measured one, and the stated range covers the measured number.
By their numbers in this assay, from the lowest: compounds 3 and 1 (each within the scatter of the next); then compounds 4 and 2 (each within the scatter of the next).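

In this assay, going by these compounds alone, this is the first view of the aromatic carbon opposite the ring nitrogen, and the exchange of 4-methoxyphenyl for 3-fluorophenyl there gives a 1.1-fold lower number from compound 2 to compound 4 (0.05 log units; within the scatter), so the two compounds cannot be told apart on this read-out. Earlier steps changed only the group on the sulfonyl sulfur, and some of those went beyond the scatter, whereas this single exchange at a different place on the shared core does not, even though it replaces the substituent on the phenyl ring and also moves it to another ring position. The data hold no independent measurement that could explain this result, and they cannot separate the contribution of the substituent from that of its ring position.

On these data alone, this comparison rests on one pair with 3,4-dimethylphenyl on the sulfonyl sulfur, so it remains open whether the same exchange would behave alike with 4-fluorophenyl or 3,5-dichlorophenyl there. The compounds shown also leave open how a group of a different kind on this aromatic carbon, such as an aliphatic amine or a carboxylic acid, would read in this assay.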